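Adding a methoxy group to the phenyl of compound 3

This account rests on a few compounds, and the source may have more. Where it says the series, first, only, none or still open, it means among the compounds named here.

Three compounds have so far been measured in an ADME assay on Huh-7 cells (Homo sapiens) for cytotoxicity, read by MTT assay, with a stated time of 48 h; a lower number here means that less compound is tolerated, a higher number that more compound is tolerated:

Compound 1 `CN(C)CCCCOC(=O)Nc1ccc(Cn2nc(-c3ccncc3)c3ccccc3c2=O)cc1` gives 62700 nM.
Compound 2 `CN(C)CCCCOC(=O)Nc1ccc(Cn2nc(-c3cnn(C)c3)c3ccccc3c2=O)cc1` gives 55900 nM.
Compound 3 `CN(C)CCCCOC(=O)Nc1ccc(Cn2nc(-c3ccccc3)c3ccccc3c2=O)cc1` gives 16000 nM.

Compound 3 has the lowest number of the three, meaning the least compound is tolerated by the cells. The two steps that lead to it are a 3.5-fold lower number from compound 2 to compound 3 (0.54 log units; beyond the scatter) and a 3.9-fold lower number from compound 1 to compound 3 (0.59 log units; beyond the scatter); both are beyond the scatter, whereas compound 1 and compound 2 sit within the scatter of each other, as a 1.1-fold lower number from compound 1 to compound 2 (0.05 log units; within the scatter) shows.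

Compound 4 `COc1ccc(-c2nn(Cc3ccc(NC(=O)OCCCCN(C)C)cc3)c(=O)c3ccccc23)cc1` differs from compound 3 in one place: methoxy in place of hydrogen on an aromatic carbon. Within the data shown here, no measured step tests such a small addition to a ring; the three steps seen all exchange one whole ring for another, and the two that lie beyond the scatter are modest in size. A methoxy added to the phenyl of compound 3 is therefore expected to change this assay little, with no step beyond the scatter, and the estimated step is a 1.3-fold higher number from compound 3 to compound 4 (0.10 log units; within the scatter). For compound 4 the expected value in this assay is 20000 nM, with a range from 8000 nM to 50000 nM.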

Compound 4, half-maximal cytotoxic concentration: 20300 nM
The estimate for compound 4 lay 1.0-fold (0.01 log units) below the measured number; low and high end bracket the measured number.
By their numbers in this assay, from the lowest: compounds 3 and 4 (each within the scatter of the next); then compounds 2 and 1 (each within the scatter of the next).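

In this assay, among these compounds, the methoxy on the phenyl ring, para to a large group, gives a 1.3-fold higher number from compound 3 to compound 4 (0.10 log units; within the scatter), so this is the first sign that a small addition to this ring, rather than the exchange of one whole ring for another, need not move the number beyond the scatter. The 4-methoxyphenyl ring also stays apart from the two rings that contain nitrogen, with a 2.8-fold lower number from compound 2 to compound 4 (0.44 log units; beyond the scatter) and a 3.1-fold lower number from compound 1 to compound 4 (0.49 log units; beyond the scatter). Across these four compounds, then, the two rings of carbon only give lower numbers than the pyridin-4-yl and 1-methyl-1H-pyrazol-4-yl rings, and no compound shown goes against this, so the kind of ring at this position separates the compounds more than this methoxy does.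

As far as these compounds go, whether an amine or a carboxylic acid in the methoxy's place, or a methoxy elsewhere on the ring, would also leave the number within the scatter remains open. The data give no measured explanation for the gap between the two kinds of ring.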